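The source may hold more compounds than are shown below. What is called first, only, known or untested is meant among the compounds shown, and "the series" means these compounds.

Of the compounds shown here, three that share one core have been tested in an assay on CHO cells for displacement of a labelled ligand from adenosine receptor A3 (Homo sapiens), read by scintillation counting, with a stated time of 120 min, tested at 10 uM; a lower number here means less inhibition, a higher number more inhibition at the concentration tested (going by the name of the read-out). Compound 1 `Nc1scc(CN2CCN(c3cc(Cl)cc(Cl)c3)CC2)c1C(=O)c1ccc(Cl)cc1` gives 1%, compound 2 `Nc1scc(CN2CCN(c3ccc(F)cc3Cl)CC2)c1C(=O)c1ccc(Cl)cc1` gives 0%, and compound 3 `Nc1scc(CN2CCN(c3ccc(Cl)cc3F)CC2)c1C(=O)c1ccc(Cl)cc1` gives 1%. Compound 3 stands level with compound 1 at the digits printed, and together the two are the highest of the three numbers, though every gap here is small: no change at the digits printed from compound 1 to compound 3 (within the scatter), a number 1 percentage points lower from compound 1 to compound 2 (within the scatter) and a number 1 percentage points higher from compound 2 to compound 3 (within the scatter). In short, none of the three shows inhibition worth the name.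

The next compound, compound 4 `Nc1scc(CN2CCN(c3ccc([N+](=O)[O-])cc3)CC2)c1C(=O)c1ccc(Cl)cc1`, keeps the core and again exchanges the aromatic group carried by the ring nitrogen: 4-nitrophenyl in place of 4-chloro-2-fluorophenyl on an amine nitrogen in a ring.

All three measured steps bear on this change, since each of them also swaps one substituted phenyl for another at the same ring nitrogen, and each stayed within the scatter. On that basis the expected step is a number 1 percentage points higher from compound 3 to compound 4 (within the scatter), that is, no change beyond the scatter is expected. Compound 4 is therefore estimated to give 2%, with a range from -6% to 12%.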

Compound 4, a percentage reported as inhibition, at one concentration (the size of the read-out at that concentration, not a potency): 2%
The estimate for compound 4 equals the measured number at the digits printed, within the range that was stated.
By their numbers in this assay, from the lowest: compounds 2, 1, 3 and 4 (each within the scatter of the next).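

Moving from halogen-bearing phenyl groups to 4-nitrophenyl on the ring nitrogen, which brings in nitrogen and oxygen and no halogen, does not separate compound 4 from the others in this assay (a number 1 percentage points higher from compound 3 to compound 4 (within the scatter); a number 2 percentage points higher from compound 2 to compound 4 (within the scatter); a number 1 percentage points higher from compound 1 to compound 4 (within the scatter)). The earlier compounds shown here covered only chlorine and fluorine on the phenyl ring, so this result extends the flat picture to a group of a different kind, though it holds only for these four compounds. No measurement at hand offers a reason for this flat result.

As far as these compounds go, all four compounds carry a substituted phenyl at this position, so it remains open whether a different group there, such as a carboxylic acid, an amine or a longer chain, would give real inhibition. From the compounds shown here alone, it also remains open whether changes elsewhere on the shared core would do so.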